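The source may hold more compounds than are shown below. What is called first, only, known or untested is meant among the compounds shown, and "the series" means these compounds.

Measured so far in an ADME assay on HEK293 cells for agonist activity at Toll-like receptor 8 (Homo sapiens), read by a luciferase reporter, with a stated time of 6 h; on this read-out lower numbers stand for an effect already at smaller amounts and higher numbers for an effect only at larger amounts of compound:

compound 1, `CCCCNc1nc(N)nc2cccc(OC)c12`, gives 0.1 uM
compound 2, `CCCCNc1nc(N)nc2cccc(CC3CCCC3)c12`, gives only a limit of the assay, > 25 uM
compound 3, `CCCCNc1nc(N)nc2cccc(OCCOC)c12`, gives 0.2 uM

Compound 3 holds the higher of the two numbers reported, with compound 1 nearest: the step of a 2.0-fold higher number from compound 1 to compound 3 (0.30 log units; within the scatter) stays within the scatter, so the two are not ordered against each other. For compound 2 the assay returned a limit, (the limit of > 25 uM in this assay, at which 1 of the 3 values shown sits), and no number.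

Compound 4, `CCCCNc1nc(N)nc2cccc(C(=O)NC)c12`, has not yet been measured. It differs from compound 3 at one place: methylcarbamoyl in place of 2-methoxyethoxy on an aromatic carbon.

Among the measured compounds shown here, two measured steps touch the same aromatic carbon. The step of an at least 250-fold higher number from compound 1 to compound 2 (2.39 log units; beyond the scatter) and the step of an at least 120-fold lower number from compound 2 to compound 3 (2.09 log units; beyond the scatter) are both large and both beyond the scatter, and both involve swapping an ether-type group against cyclopentylmethyl. Methylcarbamoyl has not been tried on this carbon, and nothing measured so far shows how an amide there behaves. For the measured compounds named here, the only evidence is that leaving the ether pattern has cost much. The expected step is therefore a 10-fold higher number from compound 3 to compound 4 (1.00 log units; beyond the scatter), upward, of moderate to large size, with a real chance that only a limit is returned.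

The estimate for compound 4 in this assay is 2 uM, expected to fall between 0.2 uM and 25 uM.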

Compound 4, minimum effective concentration: 0.39 uM
Estimate against measurement, compound 4: 5.1-fold (0.71 log units) above, and the stated range covers the measured number.
By their numbers in this assay, from the lowest: compounds 1, 3 and 4 (each within the scatter of the next, the first and the last beyond it). At a limit, above all of these: compound 2.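

In this assay, the amide shows that this aromatic carbon does not depend on an oxygen-linked substituent: the step of a 2.0-fold higher number from compound 3 to compound 4 (0.29 log units; within the scatter) leaves methylcarbamoyl and 2-methoxyethoxy unordered against each other. The earlier compounds shown here could not separate a general loss on leaving the ether pattern from a loss specific to cyclopentylmethyl; the step of an at least 64-fold lower number from compound 2 to compound 4 (1.80 log units; beyond the scatter) now places compound 2 alone among the four compounds, with the amide grouped with the two ethers rather than with cyclopentylmethyl. Methylcarbamoyl is not fully equal to every ether, however, since the step of a 3.9-fold higher number from compound 1 to compound 4 (0.59 log units; beyond the scatter) is modest but beyond the scatter, while compound 3 lies within the scatter of both compound 1 and compound 4.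

On these data alone, how far compound 2 lies from the other compounds stays open, since its entry is a limit of the assay and not a number: the limit of > 25 uM in this assay, at which 1 of the 4 values shown sits. Also open is whether this carbon accepts a carboxylic acid, an amine or a longer chain, and whether the amide hydrogen matters, which the corresponding dimethylamide would address.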